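Dropping the Hydroxy from the Side Chain of Compound 1

The source may report more compounds than this note shows. Statements on the series, on what has been measured and on what is new or still open speak of the compounds shown alone.

Compound 1 `CC(C)c1n[nH]c2c(NCc3ccc(-c4ccccn4)cc3)nc(SCC(O)CN)nc12` gives the lowest of the three numbers in a functional assay on HT cells (Homo sapiens) for antiproliferative activity, read by fluorescence, with a stated time of 72 h (on this read-out higher numbers stand for weaker inhibition of growth and lower numbers for stronger inhibition of growth), at 55 nM. Compound 3 `CC(C)c1n[nH]c2c(NCc3ccc(-c4ccccn4)cc3)nc(SCCCO)nc12` gives 109 nM, and a 2.0-fold higher number from compound 1 to compound 3 (0.30 log units; within the scatter). Compound 2 `CC(C)c1n[nH]c2c(NCc3ccc(-c4ccccn4)cc3)nc(SC(C)C(C)O)nc12` gives 190 nM, and a 3.5-fold higher number from compound 1 to compound 2 (0.54 log units; beyond the scatter). Compound 4 `CC(C)c1n[nH]c2c(NCc3ccc(-c4ccccn4)cc3)nc(SCCCN)nc12` differs from compound 1 by hydrogen in place of hydroxy on a saturated chain carbon bound to two saturated chain carbons. Within the data shown here, no measured step removes the hydroxy on its own, so the guidance is indirect: a change on the same chain in a 2.0-fold higher number from compound 1 to compound 3 (0.30 log units; within the scatter) stayed within the scatter, while reshaping the chain in a 3.5-fold higher number from compound 1 to compound 2 (0.54 log units; beyond the scatter) cost a modest amount. Compound 4 is therefore expected to show a 1.4-fold higher number from compound 1 to compound 4 (0.13 log units; within the scatter), a step not clearly beyond the scatter. Compound 4 is estimated at 75 nM, within a range from 30 nM to 190 nM.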

Compound 4, concentration for 50% growth inhibition: 120 nM
Beside the measured number, compound 4's estimate is 1.6-fold (0.20 log units) below it; the measured number falls inside the stated range.
By their numbers in this assay, from the lowest: compounds 1, 3, 4 and 2 (each within the scatter of the next, the first and the last beyond it).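

In this assay, removing only the hydroxy from the 3-amino-2-hydroxypropyl chain gives a modest loss (a 2.2-fold higher number from compound 1 to compound 4 (0.34 log units; beyond the scatter)), the first direct sign that this single oxygen counts while the amino stays in place. Compound 4 stands within the scatter of both compound 3 (a 1.1-fold higher number from compound 3 to compound 4 (0.04 log units; within the scatter)) and compound 2 (a 1.6-fold lower number from compound 2 to compound 4 (0.20 log units; within the scatter)), so these three chains cannot be ranked against one another here. Nothing available explains the loss.

On these data alone, whether a methoxy in place of the hydroxy would keep the number of compound 1 stays open. So does how a carboxylic acid or a longer chain in place of the 3-aminopropyl would read.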